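The source may hold more compounds than are shown below. What is called first, only, known or untested is meant among the compounds shown, and "the series" means these compounds.

Measured so far in an ADME assay for permeability, using PAMPA, with a stated time of 30 min, at pH 7.4; a higher number here means that the compound crosses the layer faster, a lower number that the compound crosses the layer more slowly:
- compound 1, `Fc1ccc(Oc2ccc3c(NCCCNCc4ccco4)ccnc3c2)cc1`: compound 1 gives 317 10^-6 cm/s
- compound 2, `CC(C)CCc1ccc2c(NCCCNCc3ccco3)ccnc2c1`: compound 2 gives 23 10^-6 cm/s
- compound 3, `CC(C)(C)c1ccc(-c2ccc3c(NCCCNCc4ccco4)ccnc3c2)cc1`: compound 3 gives 237 10^-6 cm/s

Compound 3 stands second highest of the three numbers. Its nearest neighbour is compound 1: the step of a 1.3-fold lower number from compound 1 to compound 3 (0.13 log units; within the scatter) lies within the scatter, so the two cannot be ordered. Its furthest neighbour is compound 2: the step of a 10-fold higher number from compound 2 to compound 3 (1.01 log units; beyond the scatter) is large and beyond the scatter, as is the related step of a 14-fold lower number from compound 1 to compound 2 (1.14 log units; beyond the scatter). Both large steps involve the isopentyl group on the shared core; the two compounds carrying an aryl-containing group there sit close together.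

Compound 4, `COc1ccc(-c2ccc3c(NCCCNCc4ccco4)ccnc3c2)cc1`, differs from compound 3 in one place: methoxy in place of tert-butyl on an aromatic carbon. Going by the values given here, no measured step changes a substituent on this outer ring, so the step from compound 3 to compound 4 has no direct precedent. Among the compounds with values here, the step that bears most closely on it is the one from compound 1 to compound 3, where exchanging one aryl-bearing group for another left the number within the scatter. On that basis the expected step for compound 4 is a 1.2-fold lower number from compound 3 to compound 4 (0.07 log units; within the scatter), that is, none beyond the scatter. The estimate for compound 4 in this assay is 200 10^-6 cm/s, with a range from 100 10^-6 cm/s to 350 10^-6 cm/s.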

Compound 4, apparent permeability: 237 10^-6 cm/s
For compound 4 the middle estimate is 1.2-fold (0.07 log units) below the measured one, and the stated range covers the measured number.
By their numbers in this assay, from the lowest: compound 2; then compounds 3, 4 and 1 (each within the scatter of the next).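

Going by these compounds alone, on the outer ring, at the aromatic carbon para to a large group, methoxy in place of tert-butyl gives no change at the digits printed from compound 3 to compound 4 (within the scatter) in this assay, the first measured change at this place, so replacing an all-carbon group with one that carries a hydrogen-bond acceptor leaves the read-out unmoved in this pair. The wider gap also holds with the new group: the step to the isopentyl compound reappears as a 10-fold higher number from compound 2 to compound 4 (1.01 log units; beyond the scatter), while a 1.3-fold lower number from compound 1 to compound 4 (0.13 log units; within the scatter) places compound 4 with the other aryl-containing compounds, and among the four compounds shown, none goes against this split between compound 2 and compounds 1, 3 and 4. No supporting measurement bears on the reason for this flat response or for the gap to compound 2.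

One pair on the outer ring does not establish how far the flat response extends, and a primary amine or a carboxylic acid in place of methoxy would test it at the same carbon. Also open, as far as these compounds go, is whether a longer chain than isopentyl, or a cyclohexyl ring at the same place on the shared core, would stay with compound 2 or join the aryl-containing compounds.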